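A few compounds are considered here, and "the series" means these few. Any claim that something is new, unique, unknown or untested is made for them only; others in the source may bear on it.

Measured so far in a functional assay on HCT-116 cells (Homo sapiens) for antiproliferative activity, read by MTT assay, with a stated time of 48 h; on this read-out lower numbers stand for stronger inhibition and higher numbers for weaker inhibition:
Compound 1 `N#CC1=C(N)Oc2c(N)cc3nc4ccccc4nc3c2C12C(=O)N(Cc1cnnn1-c1cccc(C(F)(F)F)c1)c1ccccc12` gives 18900 nM.
Compound 2 `CCOc1ccc(-n2nncc2CN2C(=O)C3(C(C#N)=C(N)Oc4c(N)cc5nc6ccccc6nc5c43)c3ccccc32)cc1` gives only a limit of the assay, > 50000 nM.

Compound 2 therefore stands at the weaker edge of what this assay can report: its value is a limit, not a number, and it sits at the limit of > 50000 nM in this assay, at which 1 of the 2 values shown sits. Compound 3 `N#CC1=C(N)Oc2c(N)cc3nc4ccccc4nc3c2C12C(=O)N(Cc1cnnn1-c1ccc(Cl)cc1Cl)c1ccccc12` is not yet measured. It differs from compound 2 at one place: 2,4-dichlorophenyl in place of 4-ethoxyphenyl on an aromatic nitrogen.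

Among the measured compounds shown here, only one measured step bears on this change, and only partly. The move an at least 2.6-fold higher number from compound 1 to compound 2 (0.42 log units; beyond the scatter) shows that putting 4-ethoxyphenyl on the aromatic nitrogen weakened the activity. For the measured compounds named here, compound 3 removes that 4-ethoxyphenyl again and carries 2,4-dichlorophenyl instead, a group for which no measured pair exists here. The reversal of the weakening step suggests a modest move back toward stronger inhibition, with wide uncertainty, and a real chance that this assay again reports only a limit. Compound 3 is expected at about 25000 nM, with a range from 8000 nM to 60000 nM. The expected step is then an at least 2.0-fold lower number from compound 2 to compound 3 (0.30 log units; that floor lies within the scatter).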

Compound 3, half-maximal inhibitory concentration: > 50000 nM
Compound 3 was reported as a limit; the forecaster's own chance of this, stated with the estimate: 40%; middle value at least 2.0-fold (0.30 log units) away from the limit.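

In this assay, a second replacement of 3-(trifluoromethyl)phenyl on this aromatic nitrogen, now by 2,4-dichlorophenyl, gives an at least 2.6-fold higher number from compound 1 to compound 3 (0.42 log units; beyond the scatter), so the loss of activity is not confined to 4-ethoxyphenyl. Of the three groups shown at this position, only 3-(trifluoromethyl)phenyl gives a measured number rather than a limit, and this holds whether the replacement carries an ethoxy group or two chlorine atoms. The step between compound 2 and compound 3 cannot be read, since both are reported only as the same limit, which now marks most of this small set: the limit of > 50000 nM in this assay, at which 2 of the 3 values shown sit.

On these data alone, how far compound 2 and compound 3 lie beyond that limit remains unknown, so the data cannot rank 4-ethoxyphenyl against 2,4-dichlorophenyl. Also open, as far as these compounds go, is whether a plain phenyl, a pyridine ring or a morpholine-bearing chain at this position would give a lower number than compound 1 with its 18900 nM, or whether any replacement tried here would keep a measurable value at all.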